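Swapping the anilide ring for a chloropyridine in a catechol amide

This account rests on a few compounds, and the source may have more. Where it says the series, first, only, none or still open, it means among the compounds named here.

Measured so far:
- compound 1, `COc1ccc(C(=O)Nc2ccccc2C)cc1OC1CCCC1`: 300 nM
- compound 2, `COc1ccc(C(=O)Nc2c(F)cccc2F)cc1OC1CCCCC1`: 400 nM
- compound 3, `COc1ccc(C(=O)Nc2c(Cl)cccc2Cl)cc1OC1CC2CCC1C2`: 10 nM

In an assay on isolated protein for inhibition of phosphodiesterase 4A (Sus scrofa) (on this read-out lower numbers stand for stronger inhibition and higher numbers for weaker inhibition), compound 1 gives the second highest of the three numbers; compound 2 sits within the scatter of it, while compound 3 gives a lower number that lies well beyond the scatter. Compound 4, `COc1ccc(C(=O)Nc2ccncc2Cl)cc1OC1CCCC1`, has not been measured. It differs from compound 1 in one place: 3-chloropyridin-4-yl in place of 2-methylphenyl on an amide-type nitrogen. For the measured compounds named here, no measured pair shows this change directly, so the expected size rests on the spread seen here. For compound 4 a lower number is expected in this assay, with the step of a 5.0-fold lower number from compound 1 to compound 4 (0.70 log units; beyond the scatter) beyond the scatter. The estimate for compound 4 is 60 nM, between 15 nM and 250 nM.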

Compound 4, half-maximal inhibitory concentration: 16 nM
The estimate for compound 4 lay 3.8-fold (0.57 log units) above the measured number; the measured number falls inside the stated range.
By their numbers in this assay, from the lowest: compounds 3 and 4 (each within the scatter of the next); then compounds 1 and 2 (each within the scatter of the next).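

In this assay, 3-chloropyridin-4-yl in place of 2-methylphenyl on an amide-type nitrogen gives a 19-fold lower number from compound 1 to compound 4 (1.27 log units; beyond the scatter). For the compounds shown here, this is the first pair that differs in one place only, so it shows that this group alone can shift the number by a large step while the rest of the core of compound 1 stays the same. Nothing available explains why the number falls.

Still open, from the compounds shown here alone, is whether the ring nitrogen or the chlorine accounts for the step. A plain pyridine ring without chlorine and a chlorophenyl ring, each on the same amide-type nitrogen, would separate the two.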